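Bromo on the core of a low-toxicity amide

A few compounds are considered here, and "the series" means these few. Any claim that something is new, unique, unknown or untested is made for them only; others in the source may bear on it.

Compound 1 `CCCNC(=O)C1CCN(C(=O)c2cc3scnc3n2Cc2ccc(OC)cc2)CC1`: 19100 nM
Compound 2 `CCCNC(=O)C1CCN(C(=O)c2cc3occc3n2Cc2ccc(OC)cc2)CC1`: 37200 nM
Compound 3 `CCCNC(=O)[C@H]1[C@@H]2CCC[C@H]1CN(C(=O)c1cc3sc(-c4ccccc4)nc3n1Cc1ccc(OC)cc1)C2`: > 100000 nM

In an ADME assay on HEK-293T cells (Homo sapiens) for cytotoxicity, read by luminescence and CellTiter-Glo, with a stated time of 24 h (on this read-out lower numbers stand for higher toxicity in this test and higher numbers for lower toxicity in this test), compound 1 gives 19100 nM and compound 2 gives 37200 nM, two numbers within the usual scatter of each other. The entry for compound 3 is a limit of the assay, not a number.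

Compound 4 `CCCNC(=O)C1CCN(C(=O)c2cc3sc(Br)nc3n2Cc2ccc(OC)cc2)CC1` departs from compound 1 in one place: bromo in place of hydrogen on an aromatic carbon. Within the data shown here, no measured pair shows this change alone, so the expectation rests on compound 1 at 19100 nM. The estimated change is a 1.1-fold lower number from compound 1 to compound 4 (0.03 log units; within the scatter), with none expected beyond the scatter in this assay. For compound 4 the expected value is 18000 nM, with an estimated range of 7000 nM to 50000 nM.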

Compound 4, half-maximal cytotoxic concentration: 36700 nM
Beside the measured number, compound 4's estimate is 2.0-fold (0.31 log units) below it, and the stated range covers the measured number.
By their numbers in this assay, from the lowest: compounds 1, 4 and 2 (each within the scatter of the next). At a limit, above all of these: compound 3.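

Putting bromo in place of hydrogen on this aromatic carbon, next to the ring nitrogen and next to the ring sulfur, gives a 1.9-fold higher number from compound 1 to compound 4 (0.28 log units; within the scatter) in this assay. This position therefore takes a single bromine atom with no change in this test beyond the usual scatter of repeats. Nothing measured here bears on why the step is this size.

Still open, on these data alone, is whether a chloro, an amine or a carboxylic acid on this same carbon would also stay within the scatter of compound 1.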